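The source may hold more compounds than are shown below. What is called first, only, known or untested is meant among the compounds shown, and "the series" means these compounds.

Series notes. In a physicochemical assay for solubility, using the shake flask method, in phosphate buffer, with a stated time of 24 h, at 25 degrees C, at pH 6.8 (on this read-out lower numbers stand for lower solubility and higher numbers for higher solubility), compound 1 `CCc1nc(O)c2c[nH]nc2n1` gives 710 ug/mL and compound 2 `CCCc1nc(O)c2c[nH]nc2n1` gives 2070 ug/mL. Compound 3 `CC(=O)n1ncc2c(=O)[nH]cnc21` stands only as a limit, > 65 ug/mL in this assay, and not as a measured number.

Compound 4 `CCCC(=O)n1ncc2c(=O)[nH]cnc21` differs from compound 3 by ethyl in place of hydrogen on a saturated chain carbon bound to a carbonyl carbon, or acetyl to propylcarbonyl.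

Going by the values given here, only one measured step bears on this change: a 2.9-fold higher number from compound 1 to compound 2 (0.46 log units; beyond the scatter). It is methyl in place of hydrogen at another place in the structure, so it is a loose guide, and a single step sets no pattern. Its direction is carried over with caution, and a modest rise is expected rather than a large one. The expected change is a step that the limit leaves unreadable from compound 3 to compound 4, an estimate that starts from a limit and is correspondingly uncertain.

Compound 4 is estimated at 150 ug/mL, with an expected range of 40 ug/mL to 700 ug/mL.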

Compound 4, solubility: > 65 ug/mL
Compound 4: a limit, no number; the forecaster's own chance of this, stated with the estimate: 30%; the middle value lies beyond the limit too.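

No step can be read from compound 3 to compound 4 in this assay since both stand only as limits, not numbers: the limit of > 65 ug/mL in this assay, at which 2 of the 4 values shown sit. The compounds shown leave open where compound 3 and compound 4 truly lie, and whether acetyl to propylcarbonyl changes the read-out at all.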